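Swapping the Aryl on the Ring Nitrogen: Compound 4

This account rests on a few compounds, and the source may have more. Where it says the series, first, only, none or still open, it means among the compounds named here.

Measured so far:
compound 1 `N#CC1=C(N)Oc2c(N)cc3nc4ccccc4nc3c2C12C(=O)N(Cc1cnnn1-c1ccccc1Cl)c1ccccc12` gives 29800 nM in a functional assay on A549 cells (Homo sapiens) for antiproliferative activity, read by MTT assay, with a stated time of 48 h; a lower number here means a stronger inhibitor, a higher number a weaker inhibitor;
compound 2 `N#CC1=C(N)Oc2c(N)cc3nc4ccccc4nc3c2C12C(=O)N(Cc1cnnn1-c1cccc(C(F)(F)F)c1)c1ccccc12` gives 5400 nM in this assay;
compound 3 `CCOc1ccccc1-n1nncc1CN1C(=O)C2(C(C#N)=C(N)Oc3c(N)cc4nc5ccccc5nc4c32)c2ccccc21` gives > 50000 nM in this assay, which is a limit of the assay.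

Compound 3 thus stands at the floor of the three (the limit of > 50000 nM in this assay, at which 1 of the 3 values shown sits), known only as a limit. Compound 4 `N#CC1=C(N)Oc2c(N)cc3nc4ccccc4nc3c2C12C(=O)N(Cc1cnnn1-c1ccc([N+](=O)[O-])cc1)c1ccccc12` differs from it by 4-nitrophenyl in place of 2-ethoxyphenyl on an aromatic nitrogen. Three measured steps change the aryl on that ring nitrogen: a 5.5-fold lower number from compound 1 to compound 2 (0.74 log units; beyond the scatter), an at least 1.6-fold higher number from compound 1 to compound 3 (0.22 log units; that floor lies within the scatter), and an at least 9.2-fold higher number from compound 2 to compound 3 (0.96 log units; beyond the scatter). Compounds 1 and 3 both carry a phenyl with a 2-substituent, and compound 2 with the 3-(trifluoromethyl)phenyl gives the lowest number. A 4-nitrophenyl is a new pattern, so a modest downward step is expected, an at least 4.1-fold lower number from compound 3 to compound 4 (0.61 log units; beyond the scatter). Compound 4 is estimated at 12000 nM, within 3000 nM to 50000 nM.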

Compound 4, half-maximal inhibitory concentration: > 50000 nM
Compound 4: no number, only a limit; the forecaster's own chance of this, stated with the estimate: 30%; middle value at least 4.1-fold (0.61 log units) from the limit.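

In this assay compound 4 gives > 50000 nM, which is a limit of the assay. A phenyl without a 2-substituent therefore does not by itself reach the level of compound 2, with an at least 9.2-fold higher number from compound 2 to compound 4 (0.96 log units; beyond the scatter), whereas an at least 1.6-fold higher number from compound 1 to compound 4 (0.22 log units; that floor lies within the scatter) stays a floor within the scatter. The step from compound 3 to compound 4 cannot be read, as neither compound has a number: the limit of > 50000 nM in this assay, at which 2 of the 4 values shown sit.

The compounds shown leave open whether the lower number of compound 2 depends on the trifluoromethyl group itself or on where it sits. They also leave open whether an amine on that phenyl would lower the number.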